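This account rests on a few compounds, and the source may have more. Where it says the series, first, only, none or still open, it means among the compounds named here.

In a functional assay on L929 cells (Mus musculus) for antiproliferative activity, read by MTT assay (on this read-out lower numbers stand for stronger inhibition and higher numbers for weaker inhibition), compound 1 (`C[C@@H]1[C@H]2CC(=O)[C@H](C)[C@H]2C[C@H]1O[Si](c1ccccc1)(c1ccccc1)C(C)(C)C`) gives 7400 nM. Compound 3 (`C[C@@H]1[C@@H]2[C@@H](CC(=O)[C@H]2C)C[C@H]1O[Si](c1ccccc1)(c1ccccc1)C(C)(C)C`) gives 14800 nM, a value within the scatter of compound 1, so the two cannot be ranked. Compound 2 (`C=CC[C@H]1C(=O)C[C@@H]2[C@@H](C)[C@H](O[Si](c3ccccc3)(c3ccccc3)C(C)(C)C)C[C@@H]21`) gives 17800 nM, which is separated from compound 1 by more than the scatter but not from compound 3. Compound 1 therefore sits at the stronger end of this small set, sharing that place with compound 3.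

Compound 4 (`C=CC[C@@H]1[C@H]2CC(=O)[C@H](C)[C@H]2C[C@H]1O[Si](c1ccccc1)(c1ccccc1)C(C)(C)C`) has not yet been measured. It comes from compound 1 by one change: vinyl in place of hydrogen on a saturated chain carbon bound to a saturated ring carbon. Cut one bond further out, this reads as methyl to allyl.

Going by the values given here, only one measured step bears on this change, a 2.4-fold higher number from compound 1 to compound 2 (0.38 log units; beyond the scatter). That step is the same kind of swap, vinyl in place of hydrogen on a saturated chain carbon bound to a saturated ring carbon, but it falls on a different carbon of the core. It is modest, and a single example is thin evidence, so the forecast stays loose. A similar move toward weaker inhibition seems the likeliest outcome, with no change beyond the scatter also possible.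

The expected step is a 2.2-fold higher number from compound 1 to compound 4 (0.33 log units; beyond the scatter). For compound 4 the estimated value is 16000 nM, with an expected range from 7000 nM to 35000 nM.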

Compound 4, half-maximal inhibitory concentration: 32400 nM
Compound 4: middle estimate off by 2.0-fold (0.31 log units), on the low side, within the range that was stated.
By their numbers in this assay, from the lowest: compounds 1, 3, 2 and 4 (each within the scatter of the next, the first and the last beyond it).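

In this assay, the methyl to allyl change at this position gives a 4.4-fold higher number from compound 1 to compound 4 (0.64 log units; beyond the scatter), so the number rises here too. Together with a 2.4-fold higher number from compound 1 to compound 2 (0.38 log units; beyond the scatter), this makes two examples, on two different carbons of the core, in which the same swap moves the number in the same direction, and no compound shown goes against this; compound 2 and compound 4 lie within the scatter of each other, so neither carbon can be called the more sensitive one. No measurement available here explains why inhibition weakens when the allyl group is present.

The compounds shown leave open whether the double bond of the allyl group matters at all, a question that a propyl group in the same place could answer, and whether a smaller ethyl group would already bring part of the step. Also open, going by these compounds, is how a group of a different kind, such as an amine or a carboxylic acid at the end of the chain, would read at this position.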